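Methyl in Place of Methoxy: What Compound 4 May Show

A few compounds are considered here, and "the series" means these few. Any claim that something is new, unique, unknown or untested is made for them only; others in the source may bear on it.

Compound 1 `COc1ccccc1COc1ccccc1/C=C/C=C1\SC(=S)NC1=O` was examined in a functional assay on DLD-1 cells (Homo sapiens), read by microscopy and crystal violet staining, with a stated time of 20 h, tested at 10 ug/mL (on this read-out lower numbers stand for less inhibition and higher numbers for more inhibition at the one concentration tested (going by the name of the read-out)), where compound 1 gives 98%. This is the highest of the three numbers recorded. The nearest is compound 3 `O=C1NC(=S)S/C1=C\C=C\c1cc(Br)ccc1OCc1ccccc1Br`, which in this assay gives 71%, a number lower than that of compound 1 by a margin beyond the scatter. The furthest is compound 2 `O=C1NC(=O)/C(=C/C=C/c2ccccc2OCc2ccccc2Br)S1`, which in this assay gives 50%, lower again, also beyond the scatter. Among the compounds with values here, none of the three measured compounds differs from another in only one place, so no single-change step is available among them.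

Compound 4 `Cc1ccccc1COc1ccccc1/C=C/C=C1\SC(=S)NC1=O` differs from compound 1 in exactly one place: methyl in place of methoxy on an aromatic carbon. Within the data shown here, no measured pair shows what such an exchange does here, so the expectation rests on compound 1 alone. The account expects a small downward step from compound 1 to compound 4 in this assay, a number 13 percentage points lower from compound 1 to compound 4 (beyond the scatter), of a size that may or may not exceed the scatter. Compound 4 is thus estimated at 85%, within a range from 55% to 100%.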

Compound 4, a percentage reported as inhibition, at one concentration (the size of the read-out at that concentration, not a potency): 73%
For compound 4 the middle estimate is 12 percentage points above the measured one, and the stated range covers the measured number.
By their numbers in this assay, from the lowest: compound 2; then compounds 3 and 4 (each within the scatter of the next); then compound 1.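

In this assay, the exchange of 2-methoxyphenyl for 2-methylphenyl provides the first single-change step among these compounds (a number 25 percentage points lower from compound 1 to compound 4 (beyond the scatter)). It shows that at this place, on an aromatic carbon ortho to a large group, the outcome depends on the group present: with everything else in the core of compound 1 unchanged, methyl in place of methoxy lowers the inhibition seen at the one concentration tested. No measurement given here bears on what lies behind this step.

The compounds shown leave open how other groups at this place would compare, such as a hydroxyl, an amine, a carboxylic acid or a longer chain like ethoxy. They also leave open whether the same exchange would give a step of similar size on a different core.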